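Swapping Chloro for Bromo on a Rat Activity Core

The source may hold more compounds than are shown below. What is called first, only, known or untested is meant among the compounds shown, and "the series" means these compounds.

Measured so far:
compound 1 `O=C1N=C(N2CCOCC2)CN1c1ccc(Cl)cc1` — 3 mg/kg
compound 2 `O=C1N=C(N2CCNCC2)CN1c1ccc(Cl)cc1` — 3 mg/kg

Compound 1 carries a chloro group on its aromatic ring and a morpholin-4-yl group on the carbon with a double bond to nitrogen. In a functional assay on the whole organism with Rattus norvegicus as the target (a higher number here means that more compound is needed for the effect, a lower number that less compound is needed), compound 1 gives 3 mg/kg. Compound 2 keeps the same core but has piperazin-1-yl in place of morpholin-4-yl, and in this assay compound 2 gives 3 mg/kg. Among the measured compounds shown here, the one step between them, no change at the digits printed from compound 1 to compound 2 (within the scatter), shows that this change at the carbon with a double bond to nitrogen leaves the dose unchanged within scatter. For the measured compounds named here, compound 1 therefore stands level with compound 2 on the numbers so far.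

Compound 3 `O=C1N=C(N2CCOCC2)CN1c1ccc(Br)cc1` differs from compound 1 only on the aromatic ring: bromo in place of chloro on an aromatic carbon. Going by the values given here, no measured step touches this position, so the step from compound 1 to compound 2 bears only indirectly, by showing the core tolerates a small change without moving the dose. Exchanging one halogen for another of similar size is expected to give a step like no change at the digits printed from compound 1 to compound 3 (within the scatter), that is, none beyond the scatter. Compound 3 is therefore estimated at 3 mg/kg, within a range from 1.5 mg/kg to 6 mg/kg.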

Compound 3, minimum effective dose: 100 mg/kg
For compound 3 the middle estimate is 33-fold (1.52 log units) below the measured one; the whole stated range lies below it.
By their numbers in this assay, from the lowest: compounds 1 and 2 (each within the scatter of the next); then compound 3.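

In this assay, the group on this aromatic carbon proves decisive: bromo in place of chloro gives a 33-fold higher number from compound 1 to compound 3 (1.52 log units; beyond the scatter) even though the two groups match on every count of heavy atoms, rings, hydrogen-bond donors, hydrogen-bond acceptors and net charge. The earlier change, on the carbon with a double bond to nitrogen, gave no change at the digits printed from compound 1 to compound 2 (within the scatter) and so showed only that the dose can hold steady under one change to the shared core; the new step shows that it can also shift strongly under a single exchange of halogens, at a place para to a large group. Nothing available here explains why this exchange has so large an effect.

On these data alone, it remains open whether chloro is unusually favourable here or bromo unusually poor, a question that fluoro, iodo, methyl or a nitrile on the same aromatic carbon could help to settle. As far as these compounds go, it is also open whether piperazin-1-yl in place of morpholin-4-yl would leave the dose unchanged with bromo on the ring, as it does with chloro.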